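A Methoxy Group Added to an Inactive Sulfonamide

A few compounds are considered here, and "the series" means these few. Any claim that something is new, unique, unknown or untested is made for them only; others in the source may bear on it.

Of the compounds shown here, two from this set have been tested in an assay on isolated protein for binding affinity to Apoptosis regulator Bcl-2 (Homo sapiens), read by fluorescence polarization, with stated times of 30 min and 20 min; on this read-out higher numbers stand for weaker inhibition and lower numbers for stronger inhibition. Compound 1 `COc1ccc(S(=O)(=O)NC(=O)Cc2c(C)n(-c3ccc(C)cc3)c3ccc(OC)cc23)cc1` carries a methoxy-bearing sulfonyl group together with a methylphenyl group on the shared core. In this assay compound 1 gives > 10000 nM, which is a limit of the assay rather than a number. Compound 2 `COc1ccc2c(c1)c(CC(=O)NS(=O)(=O)c1ccccc1)c(C)n2-c1ccc(-c2ccccc2)cc1` carries a plain phenylsulfonyl group and a biphenyl group on the shared core. In this assay compound 2 gives > 10000 nM, again a limit and not a measured number. The evidence so far is simply (the limit of > 10000 nM in this assay, at which 2 of the 2 values shown sit). Compound 3 `COc1ccc(S(=O)(=O)NC(=O)Cc2c(C)n(-c3ccc(-c4ccccc4)cc3)c3ccc(OC)cc23)cc1` has not yet been measured. It differs from compound 2 in one place: methoxy in place of hydrogen on an aromatic carbon. Among the compounds with values here, with both measured compounds sitting at the limit, there is no step between measured compounds from which a direction or size for this change could be read. Compound 3 is expected to remain at the limit, and the step that the limit leaves unreadable from compound 2 to compound 3 is expected to be none beyond the scatter. The estimate for compound 3 in this assay is 15000 nM, within a range from 5000 nM to 50000 nM.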

Compound 3, inhibition constant: > 10000 nM
Compound 3 gave a limit, no number; the forecaster's own chance of this, stated with the estimate: 85%; the middle value does not contradict the limit.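

No new step can be read from compound 3, whether it is set against compound 2 or against compound 1, in this assay: the limit of > 10000 nM in this assay, at which 3 of the 3 values shown sit.

The compounds shown leave open whether methoxy in place of hydrogen, or phenyl in place of methyl, changes binding at all, and whether any compound with this shared core gives a measurable value.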